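The compounds below may be only part of what the source reports. "The series", "measured", "known", "first", "only" and "open" are said of these compounds alone.

Measured in a functional assay on NCI-H322M cells (Homo sapiens) for cytotoxicity, read by sulforhodamine B assay, with a stated time of 48 h; on this read-out higher numbers stand for lower toxicity in this test and lower numbers for higher toxicity in this test:
compound 1 `ClCc1cccc(Cn2cnc3c(Cl)nc(Cl)nc32)c1` gives 15900 nM
compound 2 `ClCc1ccccc1Cn1cnc2ncnc(Cl)c21` gives 40700 nM
compound 3 `ClCc1cccc(Cn2cnc3nc(Cl)nc(Cl)c32)c1` gives 52500 nM

Compound 2 and compound 3 lie within the scatter of each other in this assay, so no order between them can be read. Compound 2 and compound 1 differ by more than the scatter, compound 1 carrying the lower number. Within the data shown here, no pair among the three differs in one place, so no measured step is available.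

Compound 4 `ClCc1ccccc1Cn1cnc2nc(Cl)nc(Cl)c21` differs from compound 2 by chloro in place of hydrogen on an aromatic carbon. The two measured compounds with two chloro groups on the core, compound 1 and compound 3, bracket the number of compound 2, so no direction beyond the scatter is expected for the step from compound 2 to compound 4. Compound 4 is therefore estimated at 32000 nM (range 10000 nM to 95000 nM), an expected step of a 1.3-fold lower number from compound 2 to compound 4 (0.10 log units; within the scatter).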

Compound 4, concentration lethal to 50% of the cells: 39800 nM
Compound 4: the middle estimate sits 1.2-fold (0.09 log units) below what was measured; the range from low to high includes it.
By their numbers in this assay, from the lowest: compound 1; then compounds 4, 2 and 3 (each within the scatter of the next).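

In this assay, among these compounds, the change to chloro in place of hydrogen on the aromatic carbon between two ring nitrogen atoms gives a 1.0-fold lower number from compound 2 to compound 4 (0.01 log units; within the scatter) and this is the only single-place step. On the background of compound 2, this position therefore shows no difference beyond the scatter between hydrogen and chloro. No supporting data bear on this result. On these data alone, whether an amine, a methoxy group or a carboxylic acid at this position would move the number beyond the scatter remains open. So does whether the chloro step keeps this size in other members of the series.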